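This account rests on a few compounds, and the source may have more. Where it says the series, first, only, none or still open, it means among the compounds named here.

Within the data shown here, in a functional assay on RAW264.7 cells (Mus musculus) for inhibition, read by Griess assay, with a stated time of 24 h (a higher number here means a weaker inhibitor, a lower number a stronger inhibitor), compound 2 `CC(=O)S[C@]12CC[C@H](O)[C@H]1C(=O)NC2=O` gives 833000 nM, the highest of the three numbers so far. Compound 1 `CC(=O)S[C@@]12CC[C@H](O)[C@@H]1C(=O)NC2=O` gives 148000 nM, and compound 3 `CC(=O)S[C@]12CCC[C@H]1C(=O)NC2=O` gives 59200 nM. Compound 4 `O=C(S[C@]12CC[C@H](O)[C@H]1C(=O)NC2=O)c1ccccc1` differs from compound 2 in one place: phenyl in place of methyl on a carbonyl carbon. Neither measured step changes that group, so they bear on it only indirectly. They show how far numbers move in this small set: a 5.6-fold higher number from compound 1 to compound 2 (0.75 log units; beyond the scatter), with the fact that compounds 1 and 2 differ only in the configuration as drawn, and a 14-fold lower number from compound 2 to compound 3 (1.15 log units; beyond the scatter), with hydrogen in place of hydroxy on a saturated ring carbon. Given the high number of compound 2, a modest move to a lower number is expected in this assay, with real uncertainty in its size. The expected change is a 2.4-fold lower number from compound 2 to compound 4 (0.38 log units; beyond the scatter). For compound 4 the estimated value is 350000 nM, with an expected range of 90000 nM to 1200000 nM.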

Compound 4, half-maximal inhibitory concentration: 65200 nM
For compound 4 the middle estimate is 5.4-fold (0.73 log units) above the measured one, outside the stated range (below it).
By their numbers in this assay, from the lowest: compounds 3 and 4 (each within the scatter of the next); then compound 1; then compound 2.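

In this assay, the carbonyl carbon whose other neighbours are sulfur proves to be a place where the number responds strongly, which neither earlier step could show, since both left that group untouched: a 13-fold lower number from compound 2 to compound 4 (1.11 log units; beyond the scatter), with phenyl in place of methyl. Nothing given here accounts for the size of this step. Going by these compounds, whether a longer chain or an amine at this place would move the number as phenyl does remains open. So does whether phenyl has the same effect on the core of compound 1 or compound 3.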